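Formyl on the Ring Nitrogen: Estimating Compound 4

The compounds below may be only part of what the source reports. "The series", "measured", "known", "first", "only" and "open" are said of these compounds alone.

Of the compounds shown here, three sharing one core have been tested in a functional assay on the whole organism (strain Wistar) for inhibition, with Rattus norvegicus as the target, read by paw edema, with a stated time of 30 min, at a dose of 50 mg/kg by the oral route; a lower number here means less inhibition, a higher number more inhibition at the dose given (going by the name of the read-out). Compound 3, `Fc1ccc(C2=NNC(c3cn(-c4ccccc4)nc3-c3ccc(Cl)c(Cl)c3)C2)cc1`, gives 45.7%. Compound 1, `O=CN1N=C(c2ccc(F)cc2)CC1c1cn(-c2ccccc2)nc1-c1ccc(Cl)c(Cl)c1`, gives 37.2% in this assay. The difference between them is formyl in place of hydrogen on an amine nitrogen in a ring, and the step was a number 8.5 percentage points lower from compound 3 to compound 1 (within the scatter). Compound 2, `Cc1ccc(C2=NNC(c3cn(-c4ccccc4)nc3-c3ccc(Cl)c(Cl)c3)C2)cc1`, gives 38.3% in this assay; it differs from compound 3 by methyl in place of fluoro on an aromatic carbon, and the step was a number 7.4 percentage points higher from compound 2 to compound 3 (within the scatter).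

Compound 4, `Cc1ccc(C2=NN(C=O)C(c3cn(-c4ccccc4)nc3-c3ccc(Cl)c(Cl)c3)C2)cc1`, has not yet been tested. It differs from compound 2 by formyl in place of hydrogen on an amine nitrogen in a ring. This is the same kind of change as that from compound 3 to compound 1; the two places differ only in that the ring atom two ring bonds from the changed nitrogen bears a 4-methylphenyl group in compound 4 and a 4-fluorophenyl group in compound 1. Because the earlier change gave a number 8.5 percentage points lower from compound 3 to compound 1 (within the scatter), a step of similar size is expected from the change here, a number 7.3 percentage points lower from compound 2 to compound 4 (within the scatter). Compound 4 is therefore estimated at 31%, with a likely range from 20% to 42%.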

Compound 4, a percentage reported as inhibition, in the whole organism at one dose (the size of the read-out at that dose, not a potency): 35.1%
The estimate for compound 4 lay 4.1 percentage points below the measured number; measured number inside the range.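

In this assay, formyl in place of hydrogen on the ring nitrogen gave a step of a number 3.2 percentage points lower from compound 2 to compound 4 (within the scatter), and set beside the earlier case this shows no real difference between the two cores: the same change on two cores in this assay, a number 8.5 percentage points lower (within the scatter) from compound 3 to compound 1 and a number 3.2 percentage points lower (within the scatter) from compound 2 to compound 4, 5.3 percentage points apart, within the scatter of two such steps

The swap of methyl for fluoro on the aromatic carbon, read with the formyl group in place, gave a number 2.1 percentage points lower from compound 1 to compound 4 (within the scatter), and it also matches its earlier counterpart: the same change on two cores in this assay, a number 7.4 percentage points higher (within the scatter) from compound 2 to compound 3 and a number 2.1 percentage points higher (within the scatter) from compound 4 to compound 1, 5.3 percentage points apart, within the scatter of two such steps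

So the formyl change carried from one core to the other without a detectable difference, but every step here lies within the scatter, which means these data do not show that formyl changes the inhibition at all, and two pairs cannot establish a rule for the series.

The compounds shown leave open whether a larger group on the ring nitrogen, such as acetyl or benzoyl, would give a step beyond the scatter. They also leave open what a methoxy group or an amine would do in place of the methyl or fluoro on the aromatic ring.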